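A Bulkier Benzyl Group on a Thiazolidinedione Scaffold

The compounds below may be only part of what the source reports. "The series", "measured", "known", "first", "only" and "open" are said of these compounds alone.

Measured so far:
Compound 1, `Nc1ccc(/C=C2\SC(=O)N(Cc3ccccc3)C2=O)cc1`: 42000 nM in a functional assay on CCRF-CEM cells (Homo sapiens) for cytotoxicity, read by cell counting, with a stated time of 3 days; a higher number here means a weaker inhibitor, a lower number a stronger inhibitor
Compound 2, `C=C(Br)C(=O)Nc1ccc(/C=C2\SC(=O)N(Cc3ccccc3)C2=O)cc1`: 2300 nM in this assay

Among the measured compounds shown here, compound 2 has the lowest number of the two, and its only neighbour is compound 1, which differs from it in one place: in this assay compound 1 gives 42000 nM, and the step is an 18-fold lower number from compound 1 to compound 2 (1.26 log units; beyond the scatter), with (1-bromoethenyl)carbonyl in place of hydrogen on a nitrogen on an aromatic ring.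

Compound 3, `C=C(Br)C(=O)Nc1ccc(/C=C2\SC(=O)N(Cc3ccc(C(C)(C)C)cc3)C2=O)cc1`, keeps that group and changes a different part of the shared core: tert-butyl in place of hydrogen on an aromatic carbon. For the measured compounds named here, no measured step touches this part of the molecule, so the only known step, the one from compound 1 to compound 2, does not bear on it; it concerns a different position and a different kind of group. Without a comparable pair, there is no basis for expecting a change beyond the scatter in this assay in either direction, and the estimate for compound 3 is therefore placed close to compound 2, as a step of a 1.2-fold lower number from compound 2 to compound 3 (0.06 log units; within the scatter). Compound 3 is expected to give about 2000 nM, in the range 700 nM to 6000 nM.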

Compound 3, half-maximal inhibitory concentration: 830 nM
Compound 3: the middle estimate sits 2.4-fold (0.38 log units) above what was measured; measured number inside the range.
By their numbers in this assay, from the lowest: compound 3; then compound 2; then compound 1.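

In this assay, the change from phenyl to 4-(tert-butyl)phenyl gives a 2.8-fold lower number from compound 2 to compound 3 (0.44 log units; beyond the scatter), which shows that this part of the molecule also affects the number, not only the nitrogen on an aromatic ring that changed in the earlier step. The step is modest beside the large one that introduced the (1-bromoethenyl)carbonyl group, but it points towards a stronger inhibitor, so a tert-butyl group on this aromatic carbon is accepted here without any loss in this assay. Nothing available explains why the number falls with this change.

A single substituent cannot show whether the gain belongs to tert-butyl itself or would also appear with a smaller group at the same place, such as a methyl, a chlorine or a methoxy group, or with a ring such as phenyl. As far as these compounds go, it also remains open whether 4-(tert-butyl)phenyl would give a similar step on the core of compound 1, where the nitrogen carries hydrogen instead of the (1-bromoethenyl)carbonyl group.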